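The source may report more compounds than this note shows. Statements on the series, on what has been measured and on what is new or still open speak of the compounds shown alone.

Compound 2 `Cc1c(/N=C/c2cccc([N+](=O)[O-])c2)c(=O)n(-c2ccccc2)n1C` and its companion compound 1 `Cc1c(/N=C/c2cccc(O)c2)c(=O)n(-c2ccccc2)n1C` share one core and differ only in the group on the pendant benzene ring. In a functional assay on HT-29 cells (Homo sapiens) for cytotoxicity, read by MTT assay, with a stated time of 72 h (on this read-out lower numbers stand for stronger inhibition and higher numbers for weaker inhibition), compound 1 gives 166000000 nM, and in the same assay compound 2 gives 741000000 nM. Going by the values given here, the one step that is drawn between them, a 4.5-fold higher number from compound 1 to compound 2 (0.65 log units; beyond the scatter), is therefore the only comparison available, and on these two numbers compound 2 stands highest, with compound 1 the nearest and lower.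

Compound 3 `Cc1c(/N=C/c2ccccc2)c(=O)n(-c2ccccc2)n1C` has not yet been measured. Its difference from compound 2 is hydrogen in place of nitro on an aromatic carbon. Among the compounds with values here, no measured pair shows exactly this change; the single measured step concerns the exchange of hydroxy for nitro at that same position, and it was modest though beyond the scatter. Since compound 3 carries neither of those groups, its number is expected to fall somewhere between the two measured ones, likely nearer compound 1 than compound 2. For compound 3 the estimated step from compound 2 is a 2.5-fold lower number from compound 2 to compound 3 (0.39 log units; beyond the scatter). Compound 3 is therefore estimated at 300000000 nM, with a range from 100000000 nM to 900000000 nM.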

Compound 3, half-maximal inhibitory concentration: 851000000 nM
For compound 3 the middle estimate is 2.8-fold (0.45 log units) below the measured one; measured number inside the range.
By their numbers in this assay, from the lowest: compound 1; then compounds 2 and 3 (each within the scatter of the next).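

Exchanging nitro for hydrogen on this aromatic carbon leaves the number in this assay within the scatter (a 1.1-fold higher number from compound 2 to compound 3 (0.06 log units; within the scatter)), so here the two groups cannot be told apart. The hydroxy group of compound 1 now stands out against hydrogen as well as against nitro (a 5.1-fold higher number from compound 1 to compound 3 (0.71 log units; beyond the scatter)), which shows that the earlier step (a 4.5-fold higher number from compound 1 to compound 2 (0.65 log units; beyond the scatter)) is not specific to nitro, and compound 1 is the only one of the three whose number is set apart from the others beyond the scatter. No measurement is at hand that would explain why hydroxy differs from the other two groups.

Going by these compounds alone, these three compounds vary only a single group at one place on the pendant benzene ring, so a hydroxy group is the only substituent seen to lower the number, and that on one compound alone. As far as these compounds go, it remains open whether an amine, a methoxy group or a carboxylic acid at this place would group with compound 1 or with compound 2 and compound 3, and whether hydroxy would give the same result on another carbon of the ring.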